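The compounds below may be only part of what the source reports. "The series", "measured", "known", "first", "only" and "open" are said of these compounds alone.

Working notes on the series. Going by the values given here, in a functional assay on HT-29 cells (Homo sapiens) for inhibition, with a stated time of 72 h (on this read-out lower numbers stand for stronger inhibition and higher numbers for weaker inhibition), compound 1 (`COc1ccc(S(=O)(=O)N2CCc3cccc(-c4ccc(F)c(F)c4)c32)cc1`) gives 57 nM, the lowest number so far. Compound 2 (`COc1ccc(S(=O)(=O)n2ccc3cccc(-c4ccc(C#N)cc4)c32)cc1`) gives 164 nM, a gap beyond the scatter. These two differ in more than one place, so the pair isolates no single change.

Compound 3 (`COc1ccc(S(=O)(=O)N2CCc3cccc(-c4cccnc4)c32)cc1`) has not yet been measured. It carries pyridin-3-yl in place of 3,4-difluorophenyl on an aromatic carbon. Among the compounds with values here, no measured step covers this exchange, so the expectation is loose. With compound 2 at 164 nM as the only other reference, a weaker result than that of compound 1 is expected, probably beyond the scatter. The expected change is a 2.6-fold higher number from compound 1 to compound 3 (0.42 log units; beyond the scatter), in the direction of a higher number. The estimated value for compound 3 is 150 nM, with an expected range from 50 nM to 500 nM.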

Compound 3, half-maximal inhibitory concentration: 76.3 nM
Beside the measured number, compound 3's estimate is 2.0-fold (0.29 log units) above it; low and high end bracket the measured number.
By their numbers in this assay, from the lowest: compounds 1 and 3 (each within the scatter of the next); then compound 2.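

In this assay, going by these compounds alone, the exchange of 3,4-difluorophenyl for pyridin-3-yl on this aromatic carbon gives a 1.3-fold higher number from compound 1 to compound 3 (0.13 log units; within the scatter), the first single change that can be read. At this position, a six-membered aromatic ring with a hetero atom and no fluorine therefore cannot be told apart from the 3,4-difluorophenyl ring on this read-out, even though the entering group has fewer heavy atoms and adds a hydrogen-bond acceptor. Nothing available on the series bears on the reason for this result.

On these data alone, whether a non-aromatic group at this position, such as a morpholine or a carboxylic acid, would stay within the scatter remains open. Compound 2 still differs from compound 1 and compound 3 in more than one place, so its higher number cannot be assigned to any single change.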